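The compounds below may be only part of what the source reports. "The series", "measured", "known", "first", "only" and "open" are said of these compounds alone.

Working notes on the series. Among the compounds with values here, compound 1 `NC(=O)c1ccc(-c2cccnc2)cc1` gives 8800 nM in an assay on cells for inhibition of MAP kinase-interacting serine/threonine-protein kinase 1 (Homo sapiens), read by mobility shift assay, with stated times of 10 min and 60 min, in the presence of a further agent that is not named here (on this read-out lower numbers stand for stronger inhibition and higher numbers for weaker inhibition), and stands highest of the two numbers measured so far. Its nearest neighbour is compound 2 `NC(=O)c1ccc(-c2cccnc2)cc1OC1CCNC1`, which in this assay gives 1900 nM. Within the data shown here, the single measured step is a 4.6-fold lower number from compound 1 to compound 2 (0.67 log units; beyond the scatter). Compound 3 `COc1cncc(-c2ccc(C(N)=O)cc2)c1` is not yet measured. It differs from compound 1 by methoxy in place of hydrogen on an aromatic carbon, the group entering on an aromatic carbon of a six-membered aromatic ring with 1 nitrogen, two atoms from the ring nitrogen. Among the measured compounds shown here, the measured step from compound 1 to compound 2 concerns a different group at a different place, so it bears on the present change only loosely; no step on this ring exists. For compound 3 in this assay no change beyond the scatter is expected, the expected step being a 1.4-fold lower number from compound 1 to compound 3 (0.13 log units; within the scatter). Compound 3 is therefore estimated at 6500 nM, within 2200 nM to 20000 nM.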

Compound 3, half-maximal inhibitory concentration: 3000 nM
Compound 3: middle estimate off by 2.2-fold (0.34 log units), on the high side; measured number inside the range.
By their numbers in this assay, from the lowest: compounds 2 and 3 (each within the scatter of the next); then compound 1.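

In this assay there is a 2.9-fold lower number from compound 1 to compound 3 (0.47 log units; beyond the scatter), the first step measured on the six-membered aromatic ring with 1 nitrogen, so methoxy two atoms from the ring nitrogen is a change that registers beyond the scatter. With a 4.6-fold lower number from compound 1 to compound 2 (0.67 log units; beyond the scatter) at a different place, a lower number now follows substitution at two separate places on the core of compound 1, and no compound shown goes against this. Nothing measured accounts for the step on this ring.

Going by these compounds, whether the lower number is specific to methoxy stays open: a hydroxyl, an amine or a longer chain such as ethoxy on the same carbon would test this. Also open, on these data alone, is whether methoxy and (pyrrolidin-3-yl)oxy would add up when carried together on the shared core.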